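A few compounds are considered here, and "the series" means these few. Any claim that something is new, unique, unknown or untested is made for them only; others in the source may bear on it.

Working notes on the series. In a functional assay on MDA-MB-231 cells (Homo sapiens) for inhibition, read by MTT assay, with a stated time of 48 h (a higher number here means a weaker inhibitor, a lower number a stronger inhibitor), compound 1 `COc1cc(/C=C/C(=O)Nc2ccccc2N)ccc1OCC(=O)Nc1cccc(F)c1` reads > 100000 nM as a limit of the assay, not a number. This puts it at the limit of > 100000 nM in this assay, at which 1 of the 3 values shown sits, and leaves no exact starting point.

The change to compound 4 `COc1ccc(NC(=O)COc2ccc(/C=C/C(=O)Nc3ccccc3N)cc2OC)cc1` is 4-methoxyphenyl in place of 3-fluorophenyl on an amide-type nitrogen and keeps the 2-aminophenyl group. Going by the values given here, the one measured step, an at least 68-fold lower number from compound 1 to compound 2 (1.83 log units; beyond the scatter) for compound 2 `COc1cc(/C=C/C(=O)NO)ccc1OCC(=O)Nc1cccc(F)c1` at 1450 nM in this assay, is large but replaces that 2-aminophenyl group with hydroxy on the other amide-type nitrogen. It therefore says little about the present change.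

Closer evidence comes from compound 3 `COc1cc(/C=C/C(=O)Nc2ccccc2N)ccc1OCC(=O)Nc1cc(C(F)(F)F)cc(C(F)(F)F)c1`, which keeps 2-aminophenyl and differs from compound 1 on the same amide-type nitrogen as compound 4. Compound 3 gives 25300 nM as a real number. A modest step to a lower number in this assay is therefore expected, though compound 4 may also stop at the limit. The expected step is an at least 1.4-fold lower number from compound 1 to compound 4 (0.15 log units; that floor lies within the scatter), and it remains uncertain. For compound 4 the estimate is 70000 nM, with an expected range of 25000 nM to 200000 nM in this series.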

Compound 4, half-maximal inhibitory concentration: 48500 nM
Beside the measured number, compound 4's estimate is 1.4-fold (0.16 log units) above it, and the stated range covers the measured number.
By their numbers in this assay, from the lowest: compound 2; then compounds 3 and 4 (each within the scatter of the next). At a limit, above all of these: compound 1.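

At this place on the amide-type nitrogen, with the 2-aminophenyl group kept, 4-methoxyphenyl in place of 3-fluorophenyl gives a readable step: in this assay there is an at least 2.0-fold lower number from compound 1 to compound 4 (0.31 log units; beyond the scatter). The size of that step is only a floor because compound 1 stands at a limit of the assay: the limit of > 100000 nM in this assay, at which 1 of the 4 values shown sits. Compound 3 gives 25300 nM and compound 4 gives 48500 nM, values within the scatter of each other, so 4-methoxyphenyl and the 3,5-bis(trifluoromethyl)phenyl group of compound 3 cannot be ranked on this nitrogen.

Going by these compounds, it remains open whether an amine or a carboxylic acid on the phenyl ring at this nitrogen would move the number further. On these data alone, it is also open what 4-methoxyphenyl gives when hydroxy replaces 2-aminophenyl on the other amide-type nitrogen.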